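Dibromothiophene Variant of a Sulfonylurea in a Mouse Assay

The source may report more compounds than this note shows. Statements on the series, on what has been measured and on what is new or still open speak of the compounds shown alone.

The measured compounds are:
compound 1, `O=C(Nc1ccc(Cl)cc1)NS(=O)(=O)c1ccc(Cl)s1`, 58%;
compound 2, `CCCOc1ccc(S(=O)(=O)NC(=O)Nc2ccc(Cl)cc2)s1`, 44%;
compound 3, `COc1csc(S(=O)(=O)NC(=O)Nc2ccc(Cl)cc2)c1`, 36%.

In a functional assay on the whole organism (6C3HED cells, Mus musculus) for inhibition, at a dose of 150 mg/kg by the oral route (on this read-out lower numbers stand for less inhibition and higher numbers for more inhibition at the one dose given (going by the name of the read-out)), compound 1 stands highest of the three. The step of a number 14 percentage points lower from compound 1 to compound 2 (beyond the scatter) and the step of a number 22 percentage points lower from compound 1 to compound 3 (beyond the scatter) are both declines beyond the scatter, and both replace a chloro substituent with an alkoxy group on the thiophene that sits on the sulfonyl sulfur.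

Compound 4, `O=C(Nc1ccc(Cl)cc1)NS(=O)(=O)c1cc(Br)c(Br)s1`, has not been measured. Its difference from compound 1 is 4,5-dibromothiophen-2-yl in place of 5-chlorothiophen-2-yl on a sulfonyl sulfur. Unlike the two measured steps, the halogen on the thiophene is kept and a second one is added, so neither step matches this change directly. Both measured steps left compound 1 as the highest number, and there is nothing here that points to a gain. The account therefore expects a small change, a number 6 percentage points lower from compound 1 to compound 4 (within the scatter), within the scatter. For compound 4 the estimate is 52%, in the range 30% to 72%.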

Compound 4, a percentage reported as inhibition, in the whole organism at one dose (the size of the read-out at that dose, not a potency): 25%
Compound 4: middle estimate off by 27 percentage points, on the high side; measured number outside the range, below it.
By their numbers in this assay, from the lowest: compound 4; then compounds 3 and 2 (each within the scatter of the next); then compound 1.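

In this assay, among these compounds, the change to 4,5-dibromothiophen-2-yl on a sulfonyl sulfur gives a number 33 percentage points lower from compound 1 to compound 4 (beyond the scatter), so keeping halogen on the thiophene does not hold the number up at this position, even though the earlier steps had lost ground only when an alkoxy group took the place of the chloro. The dibromo group also falls short of the methoxy-bearing ring, with a number 11 percentage points lower from compound 3 to compound 4 (beyond the scatter), so among these groups on the sulfonyl sulfur, halogen does not rank above alkoxy as such. Nothing available bears on why the number fell.

Compound 4 changes the halogen and the count of halogens at once, so the compounds shown leave open which of the two goes with the loss. They also leave open how a 5-bromothiophen-2-yl group, or a thiophene carrying an amine or a carboxylic acid, would read at this place.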